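This account rests on a few compounds, and the source may have more. Where it says the series, first, only, none or still open, it means among the compounds named here.

Measured compounds in a physicochemical assay for solubility, read by HPLC, with a stated time of 24 h; a higher number here means a more soluble compound, a lower number a less soluble compound:
- compound 1 `O=C1O[C@@H](CO)CN1c1ccc(-n2cc(-c3ccccn3)cn2)c(F)c1`: 56400 nM
- compound 2 `CN1CCN(C[C@H]2CN(c3ccc(-n4cc(-c5ccccn5)cn4)c(F)c3)C(=O)O2)CC1`: 1690000 nM
- compound 3 `O=C1O[C@@H](CN2CCC(O)CC2)CN1c1ccc(-n2cc(-c3ccccn3)cn2)c(F)c1`: 45900 nM

Compound 3 gives the lowest of the three numbers, but its gap to compound 1 is within the scatter, a 1.2-fold lower number from compound 1 to compound 3 (0.09 log units; within the scatter), so the two cannot be ordered. Only compound 2 stands apart, a 37-fold lower number from compound 2 to compound 3 (1.57 log units; beyond the scatter), and likewise a 30-fold higher number from compound 1 to compound 2 (1.48 log units; beyond the scatter).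

Compound 4 `O=C1CSC(=O)N1C[C@H]1CN(c2ccc(-n3cc(-c4ccccn4)cn3)c(F)c2)C(=O)O1` differs from compound 3 by 2,4-dioxo-1,3-thiazolidin-3-yl in place of 4-hydroxypiperidin-1-yl on a saturated chain carbon bound to a saturated ring carbon. Going by the values given here, no measured step covers this exchange: the two steps that leave compound 1 or compound 2 both end at a saturated amine ring, and the entering 2,4-dioxo-1,3-thiazolidin-3-yl, with 0 hydrogen-bond donors and 3 hydrogen-bond acceptors, has no counterpart among compounds 1, 2 and 3. Among the compounds with values here, the only guidance is that the large moves in this assay so far came with the 4-methylpiperazin-1-yl, which is absent from both compound 3 and compound 4. A modest step downward is expected, a 3.1-fold lower number from compound 3 to compound 4 (0.49 log units; beyond the scatter), with wide uncertainty. Compound 4 is estimated at 15000 nM, range 3000 nM to 80000 nM.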

Compound 4, solubility: 26900 nM
Estimate against measurement, compound 4: 1.8-fold (0.25 log units) below; low and high end bracket the measured number.
By their numbers in this assay, from the lowest: compounds 4, 3 and 1 (each within the scatter of the next, the first and the last beyond it); then compound 2.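

At the place on a saturated chain carbon bound to a saturated ring carbon, this assay does not separate the 2,4-dioxo-1,3-thiazolidin-3-yl from the 4-hydroxypiperidin-1-yl (a 1.7-fold lower number from compound 3 to compound 4 (0.23 log units; within the scatter)), although a five-membered non-aromatic ring replaces a six-membered one. Going by these compounds alone, the 2,4-dioxo-1,3-thiazolidin-3-yl is the first group to stand apart from hydroxy, though only modestly (a 2.1-fold lower number from compound 1 to compound 4 (0.32 log units; beyond the scatter)), while the 4-methylpiperazin-1-yl remains alone at the top (a 63-fold lower number from compound 2 to compound 4 (1.80 log units; beyond the scatter)). No evidence is available to explain these steps.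

On these data alone, it remains open whether a piperazin-1-yl without the methyl, a morpholin-4-yl or a dimethylamino group at this place would read with compound 2 or with compounds 1, 3 and 4. Also open, as far as these compounds go, is how a carboxylic acid, or a longer chain carrying the 4-methylpiperazin-1-yl, would read here.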